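A few compounds are considered here, and "the series" means these few. Any claim that something is new, unique, unknown or untested is made for them only; others in the source may bear on it.

Compound 1 `C=CCCCCCCCC#CC#CCO`: 3.94 ug/mL
Compound 2 `C=CCCCCCCCC#CC#CCOCC(=O)O`: 4.68 ug/mL
Compound 3 `C=CCCCCCCCC#CC#CCOCC(=O)OC`: > 30 ug/mL, a limit of the assay rather than a number

All three were examined in a functional assay on SK-MEL-2 cells (Homo sapiens) for cytotoxicity; on this read-out lower numbers stand for an effect already at smaller amounts and higher numbers for an effect only at larger amounts of compound. Compound 1 stands at the lowest of the two numbers shown, with compound 2 nearest; the step of a 1.2-fold higher number from compound 1 to compound 2 (0.07 log units; within the scatter) stays within the scatter. Compound 3 reached only (the limit of > 30 ug/mL in this assay, at which 1 of the 3 values shown sits). The steps of an at least 7.6-fold higher number from compound 1 to compound 3 (0.88 log units; beyond the scatter) and an at least 6.4-fold higher number from compound 2 to compound 3 (0.80 log units; beyond the scatter) are beyond the scatter.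

Compound 4 `CCCCCCCC#CC#CCO` differs from compound 1 at the far end of the chain: hydrogen in place of vinyl on a saturated chain carbon, seven bonds along the chain from a triple-bonded carbon. Within the data shown here, every measured step changes the oxygen on a saturated carbon or the carboxyl at the other end of the molecule, so no measured step bears on this change, and the three values offer no guide to the hydrocarbon end. With nothing pointing either way, the step from compound 1 to compound 4 is expected to be none beyond the scatter, a 1.3-fold higher number from compound 1 to compound 4 (0.10 log units; within the scatter). Compound 4 is therefore estimated at 5 ug/mL, with a range from 2 ug/mL to 15 ug/mL.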

Compound 4, concentration for half-maximal effect: 4.45 ug/mL
Compound 4: the middle estimate sits 1.1-fold (0.05 log units) above what was measured; measured number inside the range.
By their numbers in this assay, from the lowest: compounds 1, 4 and 2 (each within the scatter of the next). At a limit, above all of these: compound 3.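

In this assay, among these compounds, the first look at the hydrocarbon part of the molecule shows no effect beyond the scatter: a 1.1-fold higher number from compound 1 to compound 4 (0.05 log units; within the scatter). Hydrogen in place of vinyl, on a saturated chain carbon, seven bonds along the chain from a triple-bonded carbon, therefore leaves compound 4 with cytotoxicity that cannot be told apart from that of compound 1, so for this pair the vinyl group is not needed for the effect on these cells. Nothing measured here bears on why the two compounds match.

As far as these compounds go, whether this place accepts other groups stays open, such as a longer chain, an amine or a carboxylic acid in place of vinyl. Also open, from the compounds shown here alone, is whether compound 4 would respond to a (methoxycarbonyl)methyl group on its oxygen as compound 1 does.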